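Swapping the Anilino Ring on a Shared Core

The source may hold more compounds than are shown below. What is called first, only, known or untested is meant among the compounds shown, and "the series" means these compounds.

Of the compounds shown here, two with the same core have been tested in a functional assay on PC-3 cells (Homo sapiens) for inhibition, read by MTT assay, with a stated time of 72 h; a higher number here means a weaker inhibitor, a lower number a stronger inhibitor. Compound 1 `C=CC(=O)Nc1cccc(NC(=O)CSc2nc(Nc3ccc(Br)cc3)c3ccccc3n2)c1` gives 12400 nM. Compound 2 `C=CC(=O)Nc1cccc(NC(=O)CSc2nc(Nc3ccc(C(F)(F)F)cc3)c3ccccc3n2)c1` gives 12500 nM. Among the compounds with values here, the one step between them, a 1.0-fold higher number from compound 1 to compound 2 (0.00 log units; within the scatter), changes only the group on the aromatic carbon of the anilino ring and leaves the number where it was, so compound 2 stands alongside compound 1 with nothing to separate the two.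

Compound 3 `C=CC(=O)Nc1cccc(NC(=O)CSc2nc(Nc3cc(OC)c(OC)c(OC)c3)c3ccccc3n2)c1` is not yet measured. It differs from compound 2 in one place: 3,4,5-trimethoxyphenyl in place of 4-(trifluoromethyl)phenyl on a nitrogen on an aromatic ring. Within the data shown here, the only step recorded so far that touches this ring is the one from compound 1 to compound 2, and it stayed within the scatter, yet that step exchanged one substituent for another, whereas the present change replaces the whole ring with a different one. Among the measured compounds shown here, no measured step covers a change of this kind, so the expectation rests on the flatness seen so far and carries a wide range.

Compound 3 is expected to give 12000 nM in this assay, between 4000 nM and 40000 nM, which is an estimated step of a 1.0-fold lower number from compound 2 to compound 3 (0.02 log units; within the scatter).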

Compound 3, half-maximal inhibitory concentration: > 50000 nM
Compound 3 ended at the assay's limit (the forecaster's own chance of this, stated with the estimate: 10%); middle value at least 4.1-fold (0.61 log units) away from the limit.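

The anilino position is not indifferent to every change: exchanging bromo for trifluoromethyl left the number in this assay within the scatter, but 3,4,5-trimethoxyphenyl on this nitrogen gives an at least 4.0-fold higher number from compound 2 to compound 3 (0.60 log units; beyond the scatter), and the comparison with the bromo compound gives an at least 4.0-fold higher number from compound 1 to compound 3 (0.60 log units; beyond the scatter). Within the data shown here, the flatness seen earlier therefore covered only the pair of compounds 1 and 2, and it does not carry over to this trimethoxy ring, which counts 3 hydrogen-bond acceptors where the 4-(trifluoromethyl)phenyl group counts 0. The value for compound 3 is a limit and not a number, so both steps give only a minimum size: the limit of > 50000 nM in this assay, at which 1 of the 3 values shown sits.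

From the compounds shown here alone, what remains open is which feature of the new ring goes with the weaker result, as the trimethoxy ring differs from the two earlier rings in both the kind and the number of its substituents. A phenyl ring carrying a single methoxy group, or one carrying an amine or a carboxylic acid, would help show whether one oxygen-linked group is enough to move the number or whether the full set of three is needed.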